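Adding a Methoxy to a Pair at the Detection Limit

This account rests on a few compounds, and the source may have more. Where it says the series, first, only, none or still open, it means among the compounds named here.

Compound 1 `COc1cc2c(c(OC)c1OC)CCN(CCC(=O)c1c(C)c(OC)c(OC)c(OC)c1OC)C2` gives > 1000 nM in an assay on membranes from brain for displacement of a labelled ligand from Sigma non-opioid intracellular receptor 1 (Cavia porcellus), read by scintillation counting, with a stated time of 120 min (a higher number here means a weaker inhibitor, a lower number a stronger inhibitor), which is a limit of the assay and not a number.
Compound 2 `COc1cc2c(cc1OC)CN(CCCCCC(=O)c1c(C)c(OC)c(OC)c(OC)c1OC)CC2` gives > 1000 nM in this assay, again only a limit.

Both results thus rest at the limit of > 1000 nM in this assay, at which 2 of the 2 values shown sit. Compound 2 stands at that edge with no measured number of its own, so there is no value to climb from or fall below. Compound 3 `COc1cc2c(c(OC)c1OC)CCN(CCCCCC(=O)c1c(C)c(OC)c(OC)c(OC)c1OC)C2` is compound 2 with methoxy in place of hydrogen on an aromatic carbon. Among the measured compounds shown here, no measured pair shows what this change does in this assay. Compound 1 already shares the core of compound 3 and shows only a limit, which gives no reason to expect a gain. The step from compound 2 to compound 3 is expected to be none beyond the usual scatter, a step that the limit leaves unreadable from compound 2 to compound 3. Compound 3 is expected near 3000 nM, within 800 nM to 20000 nM, most likely reported again as a limit.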

Compound 3, inhibition constant: > 1000 nM
Compound 3: no number, only a limit; the forecaster's own chance of this, stated with the estimate: 80%; the middle value is on the limit's open side.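

The step from compound 2 to compound 3 cannot be read, because both compounds show only a limit, not a number: the limit of > 1000 nM in this assay, at which 3 of the 3 values shown sit.

The compounds shown leave open how strongly any of them binds, and whether methoxy in place of hydrogen on an aromatic carbon changes that at all.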